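The source may report more compounds than this note shows. Statements on the series, on what has been measured and on what is new or still open speak of the compounds shown alone.

Of the compounds shown here, three built on the same core have been measured in a functional assay on PC-3 cells (Homo sapiens) for cytotoxicity, read by MTT assay, with a stated time of 72 h; a higher number here means a weaker inhibitor, a lower number a stronger inhibitor. Compound 1 `COc1cc2ncnc(Nc3ccc(F)c(Cl)c3)c2cc1NC(=O)N/N=C/c1ccc(F)cc1` gives 36500 nM, compound 2 `COc1cc2ncnc(Nc3ccc(F)c(Cl)c3)c2cc1NC(=O)N/N=C/c1ccc([N+](=O)[O-])cc1` gives 32400 nM, and compound 3 `COc1cc2ncnc(Nc3ccc(F)c(Cl)c3)c2cc1NC(=O)N/N=C/c1ccc(F)cc1Cl` gives 25700 nM. Compound 3 thus stands within the usual scatter of repeat measurements of both other compounds, so these numbers do not separate the three.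

The next compound, compound 4 `COc1cc2ncnc(Nc3ccc(F)c(Cl)c3)c2cc1NC(=O)N/N=C/c1cccc(Cl)c1Cl`, keeps the core and differs only in the group on a carbon with a double bond to nitrogen, with 2,3-dichlorophenyl in place of 2-chloro-4-fluorophenyl on a carbon with a double bond to nitrogen.

For the measured compounds named here, three measured steps bear on this change, since each alters that same group. Nitro in place of fluoro gave a 1.1-fold lower number from compound 1 to compound 2 (0.05 log units; within the scatter). Chloro in place of hydrogen on an aromatic carbon gave a 1.4-fold lower number from compound 1 to compound 3 (0.15 log units; within the scatter). Putting 2-chloro-4-fluorophenyl in place of 4-nitrophenyl gave a 1.3-fold lower number from compound 2 to compound 3 (0.10 log units; within the scatter). Going by the values given here, none of these steps left the scatter, although none of the measured compounds carries 2,3-dichlorophenyl. No step beyond the scatter is therefore expected in this assay, and no direction can be called with confidence. The expected change is a 1.1-fold higher number from compound 3 to compound 4 (0.02 log units; within the scatter). The estimate for compound 4 is 27000 nM, with an expected range from 14000 nM to 50000 nM.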

Compound 4, half-maximal inhibitory concentration: 24400 nM
Estimate against measurement, compound 4: 1.1-fold (0.04 log units) above; measured number inside the range.
By their numbers in this assay, from the lowest: compounds 4, 3, 2 and 1 (each within the scatter of the next).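

Putting 2,3-dichlorophenyl on the carbon with a double bond to nitrogen adds a ring with two chlorine atoms and no fluorine, and in this assay its steps from all three earlier compounds stay small (a 1.1-fold lower number from compound 3 to compound 4 (0.02 log units; within the scatter); a 1.3-fold lower number from compound 2 to compound 4 (0.12 log units; within the scatter); a 1.5-fold lower number from compound 1 to compound 4 (0.17 log units; within the scatter)). The earlier compounds shown here showed that 4-fluorophenyl, 4-nitrophenyl and 2-chloro-4-fluorophenyl could not be told apart here, and this result adds a fourth ring with a different set of substituents to that group, so the assay separates none of the four compounds. Nothing available explains why these changes make so little difference, and no measurement of any property of these groups bears on it.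

As far as these compounds go, all four compounds carry a substituted phenyl ring at this position, so it remains open whether a different kind of group there, such as a longer carbon chain, or a ring bearing an amine or a carboxylic acid, would give a step beyond the scatter. From the compounds shown here alone, it also remains open whether any change at this position can do so while the rest of the molecule stays the same.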